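Two Purine Pairs and an Amine Swap on a Weak Scaffold

The compounds below may be only part of what the source reports. "The series", "measured", "known", "first", "only" and "open" are said of these compounds alone.

Measured compounds:
compound 1 `CCCCCCC(CCO)n1cnc2c(N(C)C)ncnc21` — > 50000 nM
compound 2 `CCCCCCC(CCO)n1cnc2c(N)ncnc21` — > 50000 nM
compound 3 `CCCCCCCCC(CCO)n1cnc2c(N(C)C)ncnc21` — 21600 nM

In a functional assay on SW480 cells (Homo sapiens) for antiproliferative activity, read by MTT assay, with a stated time of 48 h (a lower number here means a stronger inhibitor, a higher number a weaker inhibitor), compound 1 gives only a limit, > 50000 nM, not a number. Compound 2 likewise gives only a limit, > 50000 nM. Going by the values given here, compound 3 is the one compound with a real number, 21600 nM, in this assay. Compound 2 is made from compound 1 by amino in place of dimethylamino on an aromatic carbon. Because both ends sit at the limit of > 50000 nM in this assay, at which 2 of the 3 values shown sit, the step that the two limits leave unreadable from compound 1 to compound 2 cannot be read. Compound 3 is made from compound 1 by ethyl in place of hydrogen on a saturated chain carbon, seven bonds along the chain from an aromatic nitrogen, and here the step is readable: an at least 2.3-fold lower number from compound 1 to compound 3 (0.36 log units; beyond the scatter).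

Compound 4, `CCCCCCCCC(CCO)n1cnc2c(N)ncnc21`, has not yet been measured. It is made from compound 3 by amino in place of dimethylamino on an aromatic carbon. The place of this change is the same, word for word, as for the change from compound 1 to compound 2, so it is the same change on the core of compound 3 rather than the core of compound 1. The earlier instance of this change gave no readable size, so nothing in the data tells the direction of the step from compound 3 to compound 4. The expectation for compound 4 therefore rests on the value of compound 3, 21600 nM, and is a step of about a 1.4-fold higher number from compound 3 to compound 4 (0.14 log units; within the scatter), with a wide band. The estimate for compound 4 in this assay is 30000 nM, between 10000 nM and 90000 nM.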

Compound 4, half-maximal inhibitory concentration: 20700 nM
Compound 4: the middle estimate sits 1.4-fold (0.16 log units) above what was measured, and the stated range covers the measured number.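

In this assay, putting amino in place of dimethylamino on the core of compound 3 gives a 1.0-fold lower number from compound 3 to compound 4 (0.02 log units; within the scatter), so on this longer-chain core the two amines cannot be told apart, while the same swap on the core of compound 1 cannot be read, since compound 1 and compound 2 each give only a limit and not a number. This means the amine swap has no readable size on one of the two cores, and the data cannot say whether it behaves alike on both. The other change, ethyl in place of hydrogen on the chain, does repeat in direction, giving an at least 2.4-fold lower number from compound 2 to compound 4 (0.38 log units; beyond the scatter) alongside its earlier step on the core of compound 1, but the sizes of the two steps cannot be compared exactly: the same change on two cores in this assay, an at least 2.3-fold lower number (0.36 log units; beyond the scatter) from compound 1 to compound 3 and an at least 2.4-fold lower number (0.38 log units; beyond the scatter) from compound 2 to compound 4; the limit leaves it open whether they differ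

The compounds shown leave open how a chain longer than that of compound 3 would read in this assay, and so whether the gain seen with the ethyl extension continues at all. They also leave open where a methylamino group or a cyclic amine such as pyrrolidine would fall on either core.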